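Demethylation of fused bicyclic amino alcohols, antagonist read-out

The compounds below may be only part of what the source reports. "The series", "measured", "known", "first", "only" and "open" are said of these compounds alone.

Measured so far in an assay on HEK293 cells for antagonist activity at Neuronal acetylcholine receptor; alpha3/beta4 (Rattus norvegicus), read by FLIPR, using a membrane potential dye; on this read-out lower numbers stand for stronger inhibition and higher numbers for weaker inhibition:
compound 1 `CN1CC[C@@H]2CC[C@H](O)C[C@@H]21` gives the limit > 300000 nM.
compound 2 `O[C@H]1CC[C@H]2CCN[C@H]2C1` gives the limit > 300000 nM.
compound 3 `CN1CCC2=CC[C@H](O)C[C@@H]21` gives the limit > 300000 nM.

All three values are limits of the assay, not numbers. The change from compound 1 to compound 2, (hydrogen in place of methyl on an amine nitrogen in a ring), gives a step that the two limits leave unreadable from compound 1 to compound 2, because both ends sit at the limit of > 300000 nM in this assay, at which 3 of the 3 values shown sit. Compound 4 `O[C@H]1CC=C2CCN[C@H]2C1` carries the same kind of change on the core of compound 3: hydrogen in place of methyl on an amine nitrogen in a ring. Around the place, compound 1 adds only that the nitrogen is two ring bonds from the ring atom that bears a fused ring. The difference between the two cores is not broken down here.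

A step that the limit leaves unreadable from compound 3 to compound 4 is expected in this assay. This rests on compound 3, whose value is only the limit > 300000 nM. Compound 4 is estimated at 400000 nM, between 150000 nM and 1500000 nM, most likely again a limit.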

Compound 4, half-maximal inhibitory concentration: > 300000 nM
Compound 4: a limit, no number (the forecaster's own chance of this, stated with the estimate: 85%); the middle value does not contradict the limit.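

No step can be read from compound 3 to compound 4, because both values are limits of the assay: the limit of > 300000 nM in this assay, at which 4 of the 4 values shown sit. The compounds shown leave open whether hydrogen in place of methyl on an amine nitrogen in a ring changes inhibition on either core.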